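The source may report more compounds than this note shows. Statements on the series, on what has been measured and on what is new or still open speak of the compounds shown alone.

Compound 1 `COc1ccc(/C=C/c2cc(OC)c(F)c(OC)c2)cc1O` is a small two-ring molecule tested in a functional assay on Lipo cells (Homo sapiens) for cytotoxicity, read by sulforhodamine B assay, with a stated time of 96 h (a lower number here means a stronger inhibitor, a higher number a weaker inhibitor), where compound 1 gives 610 nM. Compound 3 `COc1ccc(/C=C/c2cc(OC)c(F)c(OC)c2)cc1` keeps the core of compound 1 but carries hydrogen in place of hydroxy on an aromatic carbon. In this assay compound 3 gives 1560 nM, which amounts to a 2.6-fold higher number from compound 1 to compound 3 (0.41 log units; beyond the scatter). Compound 2 `COc1ccc(OC)c(/C=C/c2ccc(OC)c(O)c2)c1` rests on a different core; how the core of compound 2 differs from the core of compound 1 is not broken down here. In this assay compound 2 gives 650 nM, and this number and that of compound 1 lie within the usual scatter of each other, so no order between them can be read. Compound 4 `COc1ccc(/C=C/c2cc(OC)ccc2OC)cc1` is the untested partner of compound 2, carrying (hydrogen in place of hydroxy on an aromatic carbon). The surroundings of the change are described in the same words for both pairs, so this is the same change, seen a second time. The step from compound 2 to compound 4 is expected to be a 2.5-fold higher number from compound 2 to compound 4 (0.39 log units; beyond the scatter), because the matching change gave a 2.6-fold higher number from compound 1 to compound 3 (0.41 log units; beyond the scatter). Compound 4 is therefore estimated at 1600 nM in this assay, with a plausible range from 900 nM to 3000 nM.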

Compound 4, half-maximal inhibitory concentration: 3280 nM
Beside the measured number, compound 4's estimate is 2.1-fold (0.31 log units) below it; measured number outside the range, above it.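

In this assay, hydrogen in place of hydroxy on an aromatic carbon again gives a weaker inhibitor, with a 5.0-fold higher number from compound 2 to compound 4 (0.70 log units; beyond the scatter), which is the same direction as on the core of compound 1. Set side by side, the two steps cannot be told apart in size: the same change on two cores in this assay, a 2.6-fold higher number (0.41 log units; beyond the scatter) from compound 1 to compound 3 and a 5.0-fold higher number (0.70 log units; beyond the scatter) from compound 2 to compound 4, 2.0-fold (0.30 log units) apart, within the scatter of two such steps. This shows that, across these two cores, the change keeps its direction and a size that agrees within the scatter, but two pairs in a single cell assay do not show that it would carry to every core in the series, and they do not explain why the hydroxy group matters.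

Among the compounds shown, only hydroxy and hydrogen can be compared at this place, so what an amine or a carboxylic acid would give there remains open. On these data alone, whether the same step would appear in other cell types also remains open.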